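Replacing methoxy with hydroxy on compound 3

The compounds below may be only part of what the source reports. "The series", "measured", "known", "first", "only" and "open" are said of these compounds alone.

Measured in a functional assay on A549 cells (Homo sapiens) for antiproliferative activity, read by MTT assay, with a stated time of 72 h (on this read-out higher numbers stand for weaker inhibition and lower numbers for stronger inhibition), so far:
- compound 1 `COc1cc(-n2cnc3ccc(-c4ccc([N+](=O)[O-])cc4)cc32)cc(OC)c1OC` gives 8940 nM
- compound 2 `COc1cc(-n2cnc3ccc(-c4cccc(Cl)c4)cc32)cc(OC)c1OC` gives 7050 nM
- compound 3 `COc1ccc(-c2ccc3ncn(-c4cc(OC)c(OC)c(OC)c4)c3c2)cc1` gives > 10000 nM (a limit)

Compound 3 has no exact number, since > 10000 nM is a limit of the assay. Compound 4 `COc1cc(-n2cnc3ccc(-c4ccc(O)cc4)cc32)cc(OC)c1OC` differs from it in one place: hydrogen in place of methyl on an oxygen on an aromatic ring. The closest evidence comes from other swaps on the same outer ring: an at least 1.1-fold higher number from compound 1 to compound 3 (0.04 log units; that floor lies within the scatter) and an at least 1.4-fold higher number from compound 2 to compound 3 (0.15 log units; that floor lies within the scatter). These steps suggest little change, so no step beyond the scatter is expected in this assay. The estimated step is an at least 1.3-fold lower number from compound 3 to compound 4 (0.12 log units; that floor lies within the scatter). Compound 4 is expected at 7500 nM, within an estimated range of 3000 nM to 15000 nM.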

Compound 4, half-maximal inhibitory concentration: 5090 nM
Compound 4: middle estimate off by 1.5-fold (0.17 log units), on the high side, and the stated range covers the measured number.
By their numbers in this assay, from the lowest: compounds 4, 2 and 1 (each within the scatter of the next). At a limit, above all of these: compound 3.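

On this outer ring, the hydroxy compound gives an exact number where the methoxy compound does not: in this assay compound 3 gives > 10000 nM, which is a limit. The change to hydroxy shows an at least 1.9-fold lower number from compound 3 to compound 4 (0.29 log units; that floor lies within the scatter), and the 4-hydroxyphenyl group stays level with the other two groups, with a 1.4-fold lower number from compound 2 to compound 4 (0.14 log units; within the scatter) and a 1.8-fold lower number from compound 1 to compound 4 (0.24 log units; within the scatter). The full size of the step from methoxy to hydroxy cannot be read: the limit of > 10000 nM in this assay, at which 1 of the 4 values shown sits.

Still open, from the compounds shown here alone, is whether an amine or a carboxylic acid in this place would move the number beyond the scatter.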